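The source may hold more compounds than are shown below. What is called first, only, known or untested is meant among the compounds shown, and "the series" means these compounds.

Measured so far:
compound 1, `Nc1scc(CN2CCN(c3ccc(F)cc3Cl)CC2)c1C(=O)c1ccc(Cl)cc1`: -6.2%
compound 2, `Nc1scc(CN2CCN(c3ccc(Cl)c(C(F)(F)F)c3)CC2)c1C(=O)c1ccc(Cl)cc1`: -12%
compound 3, `Nc1scc(CN2CCN(c3ccccc3F)CC2)c1C(=O)c1ccc(Cl)cc1`: -1%

All three share one core and differ only in the aryl group on the amine nitrogen in the ring. In a functional assay on CHO cells with adenosine receptor A1 (Homo sapiens) as the target, read by cAMP accumulation and immunoassay, with a stated time of 6 min, tested at 0.1 uM (a lower number here means a stronger effect, a higher number a weaker effect of the compound at the concentration tested), compound 3 gives the highest of the three numbers. Its nearest neighbour is compound 1, and the step of a number 5.2 percentage points higher from compound 1 to compound 3 (within the scatter) lies within the scatter. Its furthest neighbour is compound 2, and the step of a number 11 percentage points higher from compound 2 to compound 3 (beyond the scatter) is the only one of the three beyond the scatter, and a modest one. The remaining step, a number 5.8 percentage points lower from compound 1 to compound 2 (within the scatter), is also within the scatter. No substitution on this aryl group has so far moved the read-out by more than a modest amount.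

Compound 4, `Nc1scc(CN2CCN(c3ccc(F)cc3F)CC2)c1C(=O)c1ccc(Cl)cc1`, carries the change (fluoro in place of hydrogen on an aromatic carbon), turning the 2-fluorophenyl of compound 3 into a 2,4-difluorophenyl. The closest measured precedent is the pair compound 1 to compound 3, where a 2-chloro-4-fluorophenyl and a 2-fluorophenyl gave numbers within the scatter of each other. A step of no more than the scatter is therefore expected for compound 4, with a number 2 percentage points lower from compound 3 to compound 4 (within the scatter).

Compound 4 is estimated at -3% in this assay, with a range from -12% to 6%.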

Compound 4, a percentage reported as activity, at one concentration (the size of the read-out at that concentration, not a potency): -17%
Compound 4: middle estimate off by 14 percentage points, on the high side; measured number below the stated range.
By their numbers in this assay, from the lowest: compounds 4, 2, 1 and 3 (each within the scatter of the next, the first and the last beyond it).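

In this assay, adding a single fluoro on the aromatic carbon para to a large group, which turns the 2-fluorophenyl into a 2,4-difluorophenyl, gives a number 16 percentage points lower from compound 3 to compound 4 (beyond the scatter), so this position can move the read-out beyond the scatter with a change of one heavy atom. The fluoro at this carbon does not settle the number alone: compound 1 also carries it, and fluoro in place of chloro gives a number 10.8 percentage points lower from compound 1 to compound 4 (beyond the scatter), so the other halogen position on the ring also counts. The step of a number 5 percentage points lower from compound 2 to compound 4 (within the scatter) places the 2,4-difluorophenyl and the 4-chloro-3-(trifluoromethyl)phenyl within the scatter of each other, so these two differently substituted aryl groups cannot be ranked in this read-out, and compound 4 cannot be called the strongest of the four.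

Nothing shown gives a reason for these steps. Still open, on these data alone, is whether a chloro, a methoxy or an amino group on that same carbon of the 2-fluorophenyl gives a step of this size, and whether the steps seen at this single concentration would carry over to a full concentration series.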